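The compounds below may be only part of what the source reports. "The series", "measured", "known", "first", "only" and "open" are said of these compounds alone.

Measured so far in an ADME assay on MDCK cells (Canis lupus familiaris) for cytotoxicity, read by microscopy, with a stated time of 72 h; a lower number here means that less compound is tolerated, a higher number that more compound is tolerated:

Compound 1 `COC(=O)C[C@H](NC(=O)OC(C)(C)C)C(=O)N(Cc1ccccc1)C1(C(=O)NCc2ccccc2)CCN(Cc2ccccc2)CC1` gives > 100000 nM, which is a limit of the assay and not a number.
Compound 2 `CC[C@H](C)[C@H](NC(=O)OC(C)(C)C)C(=O)N(Cc1ccccc1)C1(C(=O)NCc2ccccc2)CCN(Cc2ccccc2)CC1` gives > 100000 nM, also a limit of the assay.
Among the measured compounds shown here, compound 3 `COC(=O)C[C@H](NC(=O)OCc1ccccc1)C(=O)N(C1CC1)C1(C(=O)NCc2ccccc2)CCN(Cc2ccccc2)CC1` gives 20000 nM, the only plain number here.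

Compound 1 and compound 2 differ by one change: sec-butyl in place of (methoxycarbonyl)methyl on a saturated chain carbon bound to an amide-type nitrogen and a carbonyl carbon. The size of that step, a step that the two limits leave unreadable from compound 1 to compound 2, cannot be read because of the limit of > 100000 nM in this assay, at which 2 of the 3 values shown sit. Compound 4 `CC[C@H](C)[C@H](NC(=O)OCc1ccccc1)C(=O)N(C1CC1)C1(C(=O)NCc2ccccc2)CCN(Cc2ccccc2)CC1` is not yet measured. It differs from compound 3 by sec-butyl in place of (methoxycarbonyl)methyl on a saturated chain carbon bound to an amide-type nitrogen and a carbonyl carbon, the same change at the same place as the measured pair, while the difference between the core of compound 3 and the core of compound 1 is not broken down here. With no readable size from the measured pair, the expectation for the step from compound 3 to compound 4 rests only on the value of compound 3 in this assay, 20000 nM, and the step is expected to be small: a 1.5-fold higher number from compound 3 to compound 4 (0.18 log units; within the scatter). Compound 4 is therefore estimated at 30000 nM, expected between 8000 nM and 100000 nM.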

Compound 4, minimum cytotoxic concentration: > 100000 nM
Compound 4: only a limit was reported (the forecaster's own chance of this, stated with the estimate: 30%); at least 3.3-fold (0.52 log units) between middle value and limit.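

On the core of compound 3, sec-butyl in place of (methoxycarbonyl)methyl gives, in this assay, an at least 5.0-fold higher number from compound 3 to compound 4 (0.69 log units; beyond the scatter). On these data alone, compound 4 gives > 100000 nM, which is a limit of the assay and not a number, so the full size of this step stays unknown. The same change on the core of compound 1 cannot be read, so this result does not show whether the step has a similar size on both cores, and the reason is this: the limit of > 100000 nM in this assay, at which 3 of the 4 values shown sit.

As far as these compounds go, what a carboxylic acid or an amine on that same saturated chain carbon would give in this assay remains open. So does the size of this change on any core where both values fall as plain numbers.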